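This account rests on a few compounds, and the source may have more. Where it says the series, first, only, none or still open, it means among the compounds named here.

Compound 1 `O=c1cc(-c2cc(Br)c(Br)[nH]2)oc2ccccc12` gives only a limit in a functional assay on MCF7 cells (Homo sapiens) for cytotoxicity, read by MTT assay, with stated times of 6 h and 48 h (a higher number here means a weaker inhibitor, a lower number a stronger inhibitor), namely >= 100000 nM.
Compound 2 `Cn1c(-c2cc(=O)c3ccccc3o2)cc(Br)c1Br` likewise gives only a limit in this assay, >= 100000 nM.
Compound 3 `Cn1c(-c2cc(-c3ccc[nH]3)no2)cc(Br)c1Br` also gives only a limit in this assay, >= 100000 nM.

All three measured values sit at the same limit (the limit of >= 100000 nM in this assay, at which 3 of the 3 values shown sit), so the step from compound 2 to compound 1, a step that the two limits leave unreadable from compound 2 to compound 1, cannot be read; the change itself is hydrogen in place of methyl on an aromatic nitrogen. How the core of compound 3 differs from the core of compound 2 is not broken down here.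

Compound 4 `Brc1cc(-c2cc(-c3ccc[nH]3)no2)[nH]c1Br` is still to be measured in this assay. It differs from compound 3 by hydrogen in place of methyl on an aromatic nitrogen, and the surroundings of the place are described in the same words as for the change from compound 2 to compound 1, so it is the same change. The step from compound 3 to compound 4 is expected to be about a number no higher from compound 3 to compound 4 (the limit leaves the size open), which rests on the unreadable step that the two limits leave unreadable from compound 2 to compound 1 and on the limit of >= 100000 nM in this assay, at which 3 of the 3 values shown sit, at which compound 3 sits. Compound 4 is therefore estimated at 100000 nM, with a range from 30000 nM to 300000 nM, most likely reported as a limit again.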

Compound 4, half-maximal inhibitory concentration: >= 100000 nM
Compound 4 gave a limit, no number; the forecaster's own chance of this, stated with the estimate: 85%; the middle value sits exactly at the limit.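

Among these compounds, compound 3 and compound 4 both stay at a limit in this assay, so the step between them cannot be read and no new step results: the limit of >= 100000 nM in this assay, at which 4 of the 4 values shown sit.

The compounds shown leave open whether hydrogen in place of methyl on an aromatic nitrogen has any effect on cytotoxicity in this assay, since every value is a limit.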